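Naphthalen-1-yl in Place of Nitrophenyl: Is Tolerance Kept?

The source may hold more compounds than are shown below. What is called first, only, known or untested is meant among the compounds shown, and "the series" means these compounds.

Measured compounds:
- compound 1, `O=C1c2ccccc2C(=O)N1CCOC(=S)N(C(=O)c1ccc([N+](=O)[O-])cc1)c1ccc(Cl)cc1`, gives in an ADME assay on MT4 cells (Homo sapiens) for cytotoxicity, read by MTT assay (a higher number here means that more compound is tolerated, a lower number that less compound is tolerated), the value > 100000 nM, which is a limit of the assay and not a number.
- compound 2, `Cc1ccc(N(C(=O)c2ccccc2[N+](=O)[O-])C(=S)OCCN2C(=O)c3ccccc3C2=O)cc1`, gives in this assay the value 100000 nM.
- compound 3, `Cc1ccc(N(C(=O)c2ccc(Br)c(C)c2)C(=S)OCCN2C(=O)c3ccccc3C2=O)cc1`, gives in this assay the value > 100000 nM, again a limit of the assay.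

Compound 1 therefore stands at the limit of this assay, where two of the three values shown sit (the limit of > 100000 nM in this assay, at which 2 of the 3 values shown sit). Compound 4, `O=C1c2ccccc2C(=O)N1CCOC(=S)N(C(=O)c1cccc2ccccc12)c1ccc(Cl)cc1`, is not yet measured; it differs from compound 1 in one place: naphthalen-1-yl in place of 4-nitrophenyl on a carbonyl carbon.

For the measured compounds named here, one measured step touches the same kind of exchange, a different aryl group on the carbonyl carbon: a number no lower from compound 2 to compound 3 (the limit leaves the size open). Its size cannot be read, since it ends at the limit, but it shows no loss of tolerance. No step beyond the usual scatter is expected for compound 4, so compound 4 is estimated at 100000 nM, within 40000 nM to 250000 nM, most likely reported again as a limit. The expected step is a number no higher from compound 1 to compound 4 (the limit leaves the size open).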

Compound 4, half-maximal cytotoxic concentration: 6000 nM
Compound 4: middle estimate off by 17-fold (1.22 log units), on the high side; the whole stated range lies above it.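

In this assay, the aryl group on this carbonyl carbon proves not to be a free choice: naphthalen-1-yl in place of 4-nitrophenyl gives an at least 16-fold lower number from compound 1 to compound 4 (1.22 log units; beyond the scatter). The earlier compounds shown here all stood at or close to the top of the tested range, so they could not show that a change at this place can lower the tolerated concentration at all. The value of compound 1 is a limit, so this step has only a lower bound on its size: the limit of > 100000 nM in this assay, at which 2 of the 4 values shown sit.

The compounds shown cannot tell whether the drop follows from losing the 4-nitrophenyl group or from gaining naphthalen-1-yl, and a plain phenyl or a naphthalen-2-yl group on the same carbonyl carbon would help separate the two. As far as these compounds go, it also remains open whether the same exchange lowers the number when the rest of the core differs.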